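Swapping the chlorophenyl for a pyridyl ring

A few compounds are considered here, and "the series" means these few. Any claim that something is new, unique, unknown or untested is made for them only; others in the source may bear on it.

For the measured compounds named here, compound 1 `Cn1cc(/C=C2/C(=O)Nc3ccccc32)c2cc(Nc3nccc(-c4ccc(Cl)cc4)n3)ccc21` gives 5820 nM in a functional assay on U-87MG ATCC cells (Homo sapiens) for cytotoxicity, read by MTT assay, with a stated time of 48 h (on this read-out lower numbers stand for stronger inhibition and higher numbers for weaker inhibition), the lower of the two numbers measured so far. Compound 2 `Cn1cc(/C=C2/C(=O)Nc3ccccc32)c2cc(Nc3nccc(-c4ccc(F)cc4)n3)ccc21` gives 16400 nM in this assay, and the step of a 2.8-fold higher number from compound 1 to compound 2 (0.45 log units; beyond the scatter) shows that changing this outer ring moves the number beyond the scatter. Compound 3 `Cn1cc(/C=C2/C(=O)Nc3ccccc32)c2cc(Nc3nccc(-c4cccnc4)n3)ccc21` carries pyridin-3-yl in place of 4-chlorophenyl on an aromatic carbon. Going by the values given here, no measured step makes this exact change, so the only guide is that the earlier swap on the same ring weakened inhibition. The number for compound 3 is therefore expected to rise by a 2.1-fold higher number from compound 1 to compound 3 (0.31 log units; beyond the scatter), landing near 12000 nM, with a range from 4000 nM to 40000 nM.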

Compound 3, half-maximal inhibitory concentration: 14800 nM
For compound 3 the middle estimate is 1.2-fold (0.09 log units) below the measured one, and the stated range covers the measured number.
By their numbers in this assay, from the lowest: compound 1; then compounds 3 and 2 (each within the scatter of the next).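

Replacing 4-chlorophenyl with pyridin-3-yl gives a 2.5-fold higher number from compound 1 to compound 3 (0.41 log units; beyond the scatter) and shows that weaker inhibition at this position is not confined to the change from chloro to fluoro. Set against the 4-fluorophenyl ring, pyridin-3-yl gives a 1.1-fold lower number from compound 2 to compound 3 (0.04 log units; within the scatter) and cannot be told apart from it, so among these three compounds only the 4-chlorophenyl ring stands apart. Nothing given here explains these differences.

From the compounds shown here alone, whether a 4-bromophenyl or 4-methoxyphenyl ring would give a lower number than the 4-chlorophenyl ring remains open. So does whether pyridin-4-yl would match pyridin-3-yl.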